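The source may hold more compounds than are shown below. What is called first, only, known or untested is meant among the compounds shown, and "the series" means these compounds.

Values in a functional assay on HGC-27 cells (Homo sapiens) for antiproliferative activity, read by MTT assay, with stated times of 72 h and 4 h (on this read-out higher numbers stand for weaker inhibition and lower numbers for stronger inhibition), follow
- compound 1 `COc1ncc(-c2cc3c(N4CCCCC4)ncnc3s2)cc1NS(=O)(=O)c1ccc(F)cc1F` gives 1200 nM
- compound 2 `COc1ncc(-c2cc3c(N4CC5CCCC5C4)ncnc3s2)cc1NS(=O)(=O)c1ccc(F)cc1F` gives 1900 nM
- compound 3 `COc1ncc(-c2cc3c(N4CC5COCC5C4)ncnc3s2)cc1NS(=O)(=O)c1ccc(F)cc1F` gives 300 nM

Compound 3 holds the lowest number of the three at 300 nM, and it is the most potent of them in this assay. The next structure is compound 4 `COc1ncc(-c2cc3c(N4CCN(C)CC4)ncnc3s2)cc1NS(=O)(=O)c1ccc(F)cc1F`, which carries 4-methylpiperazin-1-yl in this position: a group of 7 heavy atoms (5 carbon, 2 nitrogen; one six-membered non-aromatic ring with 2 hetero atoms) in place of a group of 8 heavy atoms (6 carbon, 1 nitrogen, 1 oxygen; 2 five-membered non-aromatic rings with 1 hetero atom each), on an aromatic carbon. All three measured steps concern the same position. The change a 4.0-fold lower number from compound 1 to compound 3 (0.60 log units; beyond the scatter) is modest and beyond the scatter, as is a 6.3-fold lower number from compound 2 to compound 3 (0.80 log units; beyond the scatter). By contrast, a 1.6-fold higher number from compound 1 to compound 2 (0.20 log units; within the scatter) stays within the scatter. Among the measured compounds shown here, no measured compound carries the 4-methylpiperazin-1-yl group, so these steps bear on the change only indirectly. They show that compound 3 is the only one of the three below the others, and that both groups tried in its place gave higher numbers. A modest move toward a higher number is therefore expected, no larger than those two steps. The expected step is a 2.2-fold higher number from compound 3 to compound 4 (0.34 log units; beyond the scatter). The estimated value for compound 4 is 650 nM, with an expected range of 180 nM to 2000 nM.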

Compound 4, half-maximal inhibitory concentration: 560 nM
For compound 4 the middle estimate is 1.2-fold (0.06 log units) above the measured one, within the range that was stated.
By their numbers in this assay, from the lowest: compounds 3 and 4 (each within the scatter of the next); then compounds 1 and 2 (each within the scatter of the next).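

In this assay, a 1.9-fold higher number from compound 3 to compound 4 (0.27 log units; within the scatter) lies within the scatter, so compound 3 no longer stands alone at the low end of this position: 4-methylpiperazin-1-yl, a single six-membered ring with 2 hetero atoms, cannot be told apart from the two fused five-membered rings. Both other steps lie beyond the scatter, a 2.1-fold lower number from compound 1 to compound 4 (0.33 log units; beyond the scatter) for the direct replacement of piperidin-1-yl and a 3.4-fold lower number from compound 2 to compound 4 (0.53 log units; beyond the scatter), so the two groups with a second hetero atom, oxygen in compound 3 and nitrogen in compound 4, give the lower numbers, and none of the four compounds goes against this. No measurement at hand gives a reason for this split.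

As far as these compounds go, whether the second hetero atom must be oxygen or nitrogen remains open, as does the part played by the methyl on the ring nitrogen. Morpholin-4-yl and unsubstituted piperazin-1-yl would bear on these two points.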